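Cyclopropyl for Trifluoromethylphenyl on the Alkyne of Compound 2

The source may report more compounds than this note shows. Statements on the series, on what has been measured and on what is new or still open speak of the compounds shown alone.

Three compounds of the series have numbers in an assay on CHO cells for displacement of a labelled ligand from adenosine receptor A1 (Homo sapiens), read by scintillation counting, with a stated time of 60 min, tested at 10 uM; a lower number here means less inhibition, a higher number more inhibition at the concentration tested (going by the name of the read-out). Compound 1 `CNC(=O)[C@@]12C[C@@H]1[C@@H](n1cnc3c(NC)nc(C#Cc4ccccc4OC)nc31)[C@H](O)[C@@H]2O` gives 12%, compound 2 `CNC(=O)[C@@]12C[C@@H]1[C@@H](n1cnc3c(NC)nc(C#Cc4cccc(C(F)(F)F)c4)nc31)[C@H](O)[C@@H]2O` gives 10%, and compound 3 `CNC(=O)[C@@]12C[C@@H]1[C@@H](n1cnc3c(NC)nc(C#Cc4nccs4)nc31)[C@H](O)[C@@H]2O` gives 31%. Compound 2 sits lowest of the three: the gap a number 2 percentage points lower from compound 1 to compound 2 (within the scatter) is within the scatter, whereas a number 21 percentage points higher from compound 2 to compound 3 (beyond the scatter) and a number 19 percentage points higher from compound 1 to compound 3 (beyond the scatter) are each modest rises beyond it.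

Compound 4 `CNC(=O)[C@@]12C[C@@H]1[C@@H](n1cnc3c(NC)nc(C#CC4CC4)nc31)[C@H](O)[C@@H]2O` differs from compound 2 as follows: cyclopropyl in place of 3-(trifluoromethyl)phenyl on a triple-bonded carbon. For the measured compounds named here, no measured step exchanges a six-membered aromatic ring for a three-membered non-aromatic ring on the triple-bonded carbon. The two exchanges between six-membered aromatic rings (a number 2 percentage points lower from compound 1 to compound 2 (within the scatter)) stayed within the scatter; the exchange to 1,3-thiazol-2-yl gave a modest rise. Nothing here connects cyclopropyl to either outcome, so for compound 4 the expected step of a number 5 percentage points higher from compound 2 to compound 4 (within the scatter) is no change beyond the scatter, with a wide margin. In this assay compound 4 is estimated at 15%, expected to fall between 2% and 35%.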

Compound 4, a percentage reported as inhibition, at one concentration (the size of the read-out at that concentration, not a potency): 38%
Estimate against measurement, compound 4: 23 percentage points below; the measured number lies above the stated range.
By their numbers in this assay, from the lowest: compounds 2 and 1 (each within the scatter of the next); then compounds 3 and 4 (each within the scatter of the next).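

Notes on the triple-bonded carbon: in this assay, a three-membered non-aromatic ring can carry the number up as well, with cyclopropyl in place of 3-(trifluoromethyl)phenyl giving a number 28 percentage points higher from compound 2 to compound 4 (beyond the scatter) and cyclopropyl in place of 2-methoxyphenyl giving a number 26 percentage points higher from compound 1 to compound 4 (beyond the scatter). A rise from the substituted phenyl compounds is therefore no longer confined to 1,3-thiazol-2-yl, and an aromatic ring at this place is not required for it: cyclopropyl in place of 1,3-thiazol-2-yl gives a number 7 percentage points higher from compound 3 to compound 4 (within the scatter), which leaves these two groups unseparated. Nothing available accounts for these steps.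

Open, on these data alone, is whether a longer chain such as n-butyl, or an amine such as dimethylaminomethyl, on the triple-bonded carbon would read with the cyclopropyl and 1,3-thiazol-2-yl compounds or with the substituted phenyl compounds. As far as these compounds go, each reading stands at one concentration, so potency also stays open.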